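This account rests on a few compounds, and the source may have more. Where it says the series, first, only, none or still open, it means among the compounds named here.

In a functional assay on M14 cells (Homo sapiens) for inhibition, read by sulforhodamine B assay, with a stated time of 48 h (on this read-out lower numbers stand for stronger inhibition of growth and higher numbers for weaker inhibition of growth), three compounds of a shared indole-type core with a phenyl at the two-position have been measured. Compound 1 `N#C/C(=C\c1c(-c2ccccc2)[nH]c2ccccc12)C(=O)c1ccccc1` gives 4800 nM. Compound 2 `CC(=O)/C(=C\c1c(-c2ccccc2)[nH]c2ccccc12)S(=O)(=O)c1ccccc1` gives 521 nM. Compound 3 `COc1ccc2[nH]c(-c3ccccc3)c(C=C(C#N)C#N)c2c1` gives 2300 nM. On these three numbers compound 3 stands second highest: its nearest neighbour is compound 1, whose number lies higher by a margin beyond the usual scatter, and its furthest is compound 2, whose number lies lower by a wider margin, also beyond the scatter. Compound 2 therefore shows the strongest growth inhibition of the three and compound 1 the weakest.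

Compound 4 `COc1ccc(-c2[nH]c3ccc(OC)cc3c2C=C(C#N)C#N)cc1` has not yet been measured in this assay. It differs from compound 3 in one place: methoxy in place of hydrogen on an aromatic carbon, para to a large group on the phenyl. Going by the values given here, no measured pair in this set carries that change, so nothing in the numbers shows its direction. The step expected is a 1.2-fold lower number from compound 3 to compound 4 (0.08 log units; within the scatter), a modest one that may well fall within the scatter, with the number of compound 4 drifting somewhat lower rather than higher. Compound 4 is accordingly estimated at 1900 nM in this assay, with a range from 650 nM to 5500 nM.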

Compound 4, concentration for 50% growth inhibition: 308 nM
Beside the measured number, compound 4's estimate is 6.2-fold (0.79 log units) above it; the whole stated range lies above it.
By their numbers in this assay, from the lowest: compounds 4 and 2 (each within the scatter of the next); then compound 3; then compound 1.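

Replacing hydrogen with methoxy on an aromatic carbon, para to a large group, turns phenyl into 4-methoxyphenyl and brings a 7.5-fold lower number from compound 3 to compound 4 (0.87 log units; beyond the scatter) in this assay, so growth inhibition strengthens by a margin beyond the scatter. Going by these compounds alone, this is the first step in the set that links two measured compounds through a single change, and it shows that what this position carries can matter in this assay, which the earlier compounds, differing from one another in more than one place, could not show. No measurement is given that would account for the size of this step, so it stands as an observation on this one pair.

The compounds shown leave open whether a hydroxyl group, a fluorine atom or a longer ethoxy chain at the same place would give a step of similar size, and so whether the methoxy group itself is what counts here. They also leave open whether the same change would hold on compound 1 or compound 2, whose other groups differ from those of compound 3.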